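Thiosemicarbazone Aryl Swap: From Hydroxy to Chloro

The source may report more compounds than this note shows. Statements on the series, on what has been measured and on what is new or still open speak of the compounds shown alone.

Compound 1 `CC1=CC[C@H](C(C)(C)NC(=S)N/N=C/c2ccccc2)CC1` gives in a functional assay on NCI-H460 cells (Homo sapiens) for inhibition, read by sulforhodamine B assay, with a stated time of 48 h (on this read-out lower numbers stand for stronger inhibition of growth and higher numbers for weaker inhibition of growth), a value of 13000 nM.
Compound 2 `CC1=CC[C@H](C(C)(C)NC(=S)N/N=C/c2ccc(O)cc2)CC1` gives in this assay only the limit > 100000 nM.
Compound 3 `CC1=CC[C@H](C(C)(C)NC(=S)N/N=C/c2ccc(N(C)C)cc2)CC1` gives in this assay a value of 53400 nM.

For the measured compounds named here, compound 2 stands at the weak end of the three: it is the one compound sitting at the limit of > 100000 nM in this assay, at which 1 of the 3 values shown sits, so no number is known for it, only that limit. Against compound 1 it shows an at least 7.6-fold higher number from compound 1 to compound 2 (0.88 log units; beyond the scatter), and against compound 3 it shows an at least 1.8-fold lower number from compound 2 to compound 3 (0.27 log units; that floor lies within the scatter).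

Compound 4 `CC1=CC[C@H](C(C)(C)NC(=S)N/N=C/c2cccc(Cl)c2)CC1` has not been measured. It differs from compound 2 by 3-chlorophenyl in place of 4-hydroxyphenyl on a carbon with a double bond to nitrogen. Going by the values given here, two measured steps bear on this change, both involving the hydroxy group: an at least 7.6-fold higher number from compound 1 to compound 2 (0.88 log units; beyond the scatter), and an at least 1.8-fold lower number from compound 2 to compound 3 (0.27 log units; that floor lies within the scatter). The first step shows that putting hydroxy onto the unsubstituted phenyl of compound 1 brought a clearly higher number, so taking it away again is expected to bring the number back down. Among the compounds with values here, for chlorine on the ring no step is known, so the expected position for compound 4 is taken from compound 1, with a wide range. The estimated step is an at least 6.6-fold lower number from compound 2 to compound 4 (0.82 log units; beyond the scatter). Compound 4 is therefore expected to give about 15000 nM, between 4000 nM and 60000 nM.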

Compound 4, concentration for 50% growth inhibition: 1400 nM
Compound 4: middle estimate off by 11-fold (1.03 log units), on the high side; the measured number lies below the stated range.
By their numbers in this assay, from the lowest: compound 4; then compound 1; then compound 3. At a limit, above all of these: compound 2.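

In this assay, the earlier ring substituents had only come with higher numbers than the unsubstituted phenyl of compound 1, whereas a chlorine added to that ring goes the other way, with a 9.3-fold lower number from compound 1 to compound 4 (0.97 log units; beyond the scatter). Exchanging 4-hydroxyphenyl for 3-chlorophenyl on the carbon with a double bond to nitrogen gives an at least 71-fold lower number from compound 2 to compound 4 (1.85 log units; beyond the scatter), so the aryl group at this place can carry the series from the weak end of what is shown to the low end of the measured numbers. This step is only a floor, as compound 2 gives a limit and not a number: the limit of > 100000 nM in this assay, at which 1 of the 4 values shown sits.

From the compounds shown here alone, whether a 4-chlorophenyl ring would read like 3-chlorophenyl stays open, and with it the question of whether chlorine itself or its place on the ring carries the step. Also open, going by these compounds, is how a 3-fluorophenyl, 3-methoxyphenyl or 3-aminophenyl ring would read at this carbon, and whether a second chlorine on the ring would lower the number further.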